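A few compounds are considered here, and "the series" means these few. Any claim that something is new, unique, unknown or untested is made for them only; others in the source may bear on it.

Values so far in a physicochemical assay for lipophilicity, at pH 7.4; on this read-out higher numbers stand for higher lipophilicity and lower numbers for lower lipophilicity
- compound 1 `CNC(=O)c1cc(C(=O)N[C@H]2[C@@H]3COC[C@@H]32)cc2c1OC[C@H]2c1cccnc1` gives 1.4
- compound 2 `CNC(=O)c1cc(C(=O)NC2CC2)cc2c1OC[C@H]2c1cccc2[nH]ccc12` gives 3.5
- compound 3 `CNC(=O)c1cc(C(=O)N[C@H]2[C@@H]3COC[C@@H]32)cc2c1OC[C@H]2c1cccc2[nH]ccc12` gives 3.1

Of these three, compound 2 stands highest at 3.5. Compound 4 `CNC(=O)c1cc(C(=O)NC2CC2)cc2c1OC[C@H]2c1cccc(OC)c1` differs from it in one group: 3-methoxyphenyl in place of 1H-indol-4-yl on a saturated ring carbon. In words, 3-methoxyphenyl takes the place of 1H-indol-4-yl on a saturated ring carbon.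

Among the compounds with values here, only one measured step touches that carbon. This large step, a number 1.70 log units higher from compound 1 to compound 3 (beyond the scatter), shows that a swap there can move the number far, so the range stays wide. The modest step of a number 0.40 log units lower from compound 2 to compound 3 (beyond the scatter) is on an amide-type nitrogen and bears little on this change. Within the data shown here, no measured compound carries 3-methoxyphenyl. With one aromatic group replacing another, no step beyond the scatter is expected in this assay. The estimated change is a number 0.10 log units higher from compound 2 to compound 4 (within the scatter). For compound 4 the expected value is 3.6, within a range of 3.1 to 4.1.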

Compound 4, distribution coefficient: 3.8
Compound 4: the middle estimate sits 0.20 log units below what was measured; measured number inside the range.
By their numbers in this assay, from the lowest: compound 1; then compound 3; then compounds 2 and 4 (each within the scatter of the next).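

In this assay, putting 3-methoxyphenyl in place of 1H-indol-4-yl on this saturated ring carbon gives a number 0.30 log units higher from compound 2 to compound 4 (within the scatter). At this carbon, then, a one-ring group with a hydrogen-bond acceptor and a two-ring group with a hydrogen-bond donor read alike, unlike the swap from pyridin-3-yl, which gave a number 1.70 log units higher from compound 1 to compound 3 (beyond the scatter). Nothing measured here accounts for this result. Still open, as far as these compounds go, is what a group carrying an amine or a carboxylic acid would do at this carbon, and whether 3-methoxyphenyl reads the same alongside the amide group of compound 3.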